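A few compounds are considered here, and "the series" means these few. Any claim that something is new, unique, unknown or untested is made for them only; others in the source may bear on it.

Measured in a functional assay on the whole organism (blood, strain Wistar-Okamoto) with Rattus norvegicus as the target, with a stated time of 5 days; a higher number here means that more compound is needed for the effect, a lower number that less compound is needed:
compound 1, `CCC(CC)/N=C(\NC#N)Nc1ccncc1`, gives 2.5 mg/kg;
compound 2, `CCC(/N=C(\NC#N)Nc1ccncc1)C(C)C`, gives 5 mg/kg;
compound 3, `CC(C)CC(C)(C)/N=C(\NC#N)Nc1ccncc1`, gives 20 mg/kg.

Compound 4, `CC(C)(C)CC(C)(C)/N=C(\NC#N)Nc1ccncc1`, remains to be measured in this assay. The change from compound 1 to compound 2 is methyl in place of hydrogen on a saturated chain carbon bound to two saturated chain carbons; it made a 2.0-fold higher number from compound 1 to compound 2 (0.30 log units; within the scatter). The change from compound 3 to compound 4 is methyl in place of hydrogen on a saturated chain carbon bound to three saturated chain carbons, the same kind of change, though the place differs: in the earlier pair the carbon is bound to two saturated chain carbons, in the present pair to three. The difference between the core of compound 1 and the core of compound 3 is not broken down here; their values show compound 3 standing higher. The step from compound 3 to compound 4 in this assay is expected to be a 1.5-fold higher number from compound 3 to compound 4 (0.18 log units; within the scatter). This expectation rests on the earlier step of a 2.0-fold higher number from compound 1 to compound 2 (0.30 log units; within the scatter), with some allowance for the different place. Compound 4 is estimated at 30 mg/kg, with a range from 12 mg/kg to 80 mg/kg.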

Compound 4, minimum effective dose: 50 mg/kg
For compound 4 the middle estimate is 1.7-fold (0.22 log units) below the measured one; measured number inside the range.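

In this assay, methyl in place of hydrogen on a saturated chain carbon bound to three saturated chain carbons gives a 2.5-fold higher number from compound 3 to compound 4 (0.40 log units; beyond the scatter). Set beside the earlier step, the change carries from one core to the other with no readable difference in size: the same change on two cores in this assay, a 2.0-fold higher number (0.30 log units; within the scatter) from compound 1 to compound 2 and a 2.5-fold higher number (0.40 log units; beyond the scatter) from compound 3 to compound 4, 1.3-fold (0.10 log units) apart, within the scatter of two such steps. This rests on a single pair of steps, so it does not show that the step would hold on other cores or at other places, and it gives no reason for the size of either step.

All the compounds shown carry saturated branched chains. Going by these compounds, how a hydroxyl, an amine or a longer chain in that part of the structure would read in this assay remains open.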